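The source may hold more compounds than are shown below. What is called first, only, known or untested is meant among the compounds shown, and "the series" means these compounds.

The series shares the core of compound 1 `CCOC(=O)C(C)C(O)(c1ccc(OC)c(OC)c1OC)c1cccc2ccccc12`, carried through compound 2 `COc1ccc(C(c2ccccc2O)c2cccc3ccccc23)c(OC)c1OC` and compound 3 `COc1ccc(/C(=C\c2ccc(F)cc2)c2cccc3ccccc23)c(OC)c1OC`. In a functional assay on THP-1 cells (Homo sapiens) for inhibition, read by sulforhodamine B assay, with a stated time of 48 h (a higher number here means a weaker inhibitor, a lower number a stronger inhibitor), compound 1 gives only a limit of > 20000 nM. Compound 2 likewise gives only a limit, > 20000 nM, in this assay. Within the data shown here, compound 3 is the one member with a number in this assay, at 9080 nM. Compound 2 therefore stands at the limit of > 20000 nM in this assay, at which 2 of the 3 values shown sit, with no number of its own to set against compound 3.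

Compound 4 `COc1ccc(C(OCc2ccc(C)cc2)c2cccc3ccccc23)c(OC)c1OC` has not been measured. It differs from compound 2 by (4-methylbenzyl)oxy in place of 2-hydroxyphenyl on a saturated chain carbon bound to two aromatic carbons. Among the measured compounds shown here, no measured pair in the set differs in one place, so this step has no precedent here. Because compound 2 sits at > 20000 nM as a limit, any shift in this assay can only be judged from the side of the limit. The step from compound 2 to compound 4 is expected as a number no higher from compound 2 to compound 4 (the limit leaves the size open), nothing clearly beyond the scatter. Compound 4 is estimated at 20000 nM in this assay, with a range from 7000 nM to 60000 nM, and a limit rather than a number is the likelier outcome.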

Compound 4, half-maximal inhibitory concentration: > 20000 nM
Compound 4: no number, only a limit; the forecaster's own chance of this, stated with the estimate: 60%; the middle value lies on the limit itself.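

Compound 2 and compound 4 are both limits in this assay and not numbers, so no step between them can be read: the limit of > 20000 nM in this assay, at which 3 of the 4 values shown sit.

The compounds shown leave open whether (4-methylbenzyl)oxy in place of 2-hydroxyphenyl on a saturated chain carbon bound to two aromatic carbons changes inhibition at all.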